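The source may report more compounds than this note shows. Statements on the series, on what has been measured and on what is new or still open speak of the compounds shown alone.

Measured in a functional assay on MCF7 cells (Homo sapiens) for cytotoxicity, read by colorimetric assay and neutral red uptake, with a stated time of 72 h; a lower number here means a stronger inhibitor, a higher number a weaker inhibitor:

- Compound 1 `CO[C@@H](C(=O)N[C@H]1CCCCNC1=O)[C@@H]1OC(C)(C)O[C@H](/C=C/C(C)(C)C)[C@@H]1O`: > 150000 nM
- Compound 2 `CO[C@@H](C(=O)N[C@H]1CC[C@@H](O)CNC1=O)[C@H](O)[C@@H](O)[C@H](O)/C=C/C(C)(C)C`: 23400 nM

The entry for compound 1, > 150000 nM, is a limit of this assay and not a number. Going by the values given here, compound 2, at 23400 nM, holds the only actual number, so it is the sole firm reference point for what follows.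

Compound 3 `CO[C@@H](C(=O)N[C@@H]1CC[C@@H](O)CNC1=O)[C@H](O)[C@@H](O)[C@H](O)/C=C/C(C)(C)C` is the next to be considered against compound 2: the two compounds have the same atoms and bonds and differ only in configuration as drawn: 1 of 7 stereo elements differ; a stereocentre at a saturated ring carbon is drawn S in compound 2 and R in compound 3. A stereocentre at a saturated ring carbon is drawn S in compound 2 and R in compound 3.

Among the compounds with values here, no measured pair shows what such an inversion does in this assay, so any forecast is uncertain. A moderate loss of strength, beyond the usual scatter, is expected, although no change cannot be ruled out. The expected change is a 2.6-fold higher number from compound 2 to compound 3 (0.41 log units; beyond the scatter), an estimate towards weaker inhibition. For compound 3 the estimated value is 60000 nM, with an expected range of 20000 nM to 150000 nM.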

Compound 3, half-maximal inhibitory concentration: 165000 nM
Estimate against measurement, compound 3: 2.8-fold (0.44 log units) below; the whole stated range lies below it.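

In this assay, going by these compounds alone, the inversion of one stereocentre at a saturated ring carbon gives the first single change that can be read, a 7.1-fold higher number from compound 2 to compound 3 (0.85 log units; beyond the scatter) and towards weaker inhibition. Both ends of this step are actual numbers, so the assay clearly tells the two configurations at this carbon apart. The shift can be assigned to this one stereocentre alone because of a single fact: the fact that compounds 2 and 3 differ only in the configuration as drawn.

The compounds shown leave open what the other stereo elements contribute, and whether this inversion would have a similar effect with a different side chain. They also leave open how an amine or a carboxylic acid in place of the hydroxyl on the ring would behave at either configuration.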